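A Phenyl Branch on the Butoxy Linker

A few compounds are considered here, and "the series" means these few. Any claim that something is new, unique, unknown or untested is made for them only; others in the source may bear on it.

The shared core of compound 1 `COc1ccccc1N1CCN(CCCCOc2ccc(C(=O)Nc3ccccc3OCCCC(=O)O)cc2)CC1` binds in an assay on Prostate gland (Oryctolagus cuniculus) for inhibition of Adrenergic receptor alpha-1 (Homo sapiens) (on this read-out lower numbers stand for tighter binding and higher numbers for weaker binding), with a value of 79.4 nM. Compound 2 `COc1ccccc1N1CCN(CCC(Oc2ccc(NC(=O)c3ccccc3OCCCC(=O)O)cc2)c2ccc(C)cc2)CC1` gives 79.4 nM, level with compound 1 within the scatter, and together they stand highest of the three. Compound 3 `COc1ccccc1N1CCN(CCC(Oc2ccc(C(=O)Nc3ccccc3OCCCC(=O)O)cc2)c2ccccc2)CC1`, which carries a phenyl on the chain carbon bound to the aryl oxygen, gives 25.1 nM, a gap from compound 1 that lies beyond the scatter. Compound 4 `COc1ccccc1N1CCN(CCCC(Oc2ccc(C(=O)Nc3ccccc3OCCCC(=O)O)cc2)c2ccccc2)CC1` differs from compound 1 by phenyl in place of hydrogen on a saturated chain carbon bound to an oxygen on an aromatic ring and a saturated chain carbon. Since compound 3 shows a lower number than compound 1 with a comparable phenyl placement, a modest downward step is expected from compound 1 to compound 4, a 2.0-fold lower number from compound 1 to compound 4 (0.30 log units; within the scatter). Compound 4 is therefore estimated at 40 nM, with a range from 15 nM to 120 nM.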

Compound 4, dissociation constant: 316 nM
Estimate against measurement, compound 4: 7.9-fold (0.90 log units) below; the whole stated range lies below it.
By their numbers in this assay, from the lowest: compound 3; then compounds 1 and 2 (each within the scatter of the next); then compound 4.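

In this assay, phenyl in place of hydrogen on a saturated chain carbon bound to an oxygen on an aromatic ring and a saturated chain carbon gives a 4.0-fold higher number from compound 1 to compound 4 (0.60 log units; beyond the scatter), so on this unbranched chain the change weakens binding beyond the scatter. The same phenyl on a shorter chain stands at a much lower number: compound 3 gives 25.1 nM, whereas compound 4 gives 316 nM. Nothing available explains this step. From the compounds shown here alone, whether a methyl group or a hydroxyl group on this carbon would shift the number in the same direction remains open.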